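Dropping the methyl: from 3-methylphenyl to plain phenyl

The source may hold more compounds than are shown below. What is called first, only, known or untested is meant among the compounds shown, and "the series" means these compounds.

Measured so far:
- compound 1, `COc1cc(/C=C/C(=O)c2sc(Nc3ccc(C)cc3)nc2C)cc(OC)c1OC`: in a functional assay on NCI-H460 cells (Homo sapiens) for cytotoxicity, read by MTT assay (a lower number here means a stronger inhibitor, a higher number a weaker inhibitor), compound 1 gives only a limit, > 25000 nM.
- compound 2, `COc1cc(/C=C/C(=O)c2sc(Nc3cccc(C)c3)nc2C)cc(OC)c1OC`: in this assay compound 2 gives 19800 nM.

For the measured compounds named here, compound 2 carries the only real number here; the other value is a limit of the assay, as the limit of > 25000 nM in this assay, at which 1 of the 2 values shown sits, records, so compound 2 cannot be ranked against compound 1. Going by the values given here, the one measured step, an at least 1.2-fold lower number from compound 1 to compound 2 (0.10 log units; that floor lies within the scatter), moves the methyl around the ring and stays within the usual scatter.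

Compound 3, `COc1cc(/C=C/C(=O)c2sc(Nc3ccccc3)nc2C)cc(OC)c1OC`, is not yet measured. It differs from compound 2 by hydrogen in place of methyl on an aromatic carbon, that is, 3-methylphenyl becomes phenyl. Among the compounds with values here, no measured step removes a methyl from this ring, so the only guide is that shifting it changed little. The step is therefore expected to be small, a 1.2-fold higher number from compound 2 to compound 3 (0.08 log units; within the scatter), with a fair chance that only a limit is reported. Compound 3 is estimated at 24000 nM, within 9000 nM to 60000 nM.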

Compound 3, half-maximal inhibitory concentration: > 25000 nM
Compound 3 was reported as a limit (the forecaster's own chance of this, stated with the estimate: 45%); at least 1.0-fold (0.01 log units) between middle value and limit.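

Removing the methyl, rather than moving it, gives an at least 1.2-fold higher number from compound 2 to compound 3 (0.10 log units; that floor lies within the scatter), so the measured floor does not establish that this methyl matters for cytotoxicity. In this assay compound 3 gives > 25000 nM, which is a limit of the assay and not a number. With this result, the plain phenyl ring and the 4-methylphenyl ring both end at a limit, so the step between compound 1 and compound 3 cannot be read, and the one exact number in the set still belongs to the 3-methylphenyl ring: the limit of > 25000 nM in this assay, at which 2 of the 3 values shown sit.

The compounds shown leave open how far compound 1 and compound 3 lie from compound 2, so it remains unsettled whether the methyl on the 3-methylphenyl ring makes any real difference. They also leave open whether a different group at that place on the ring, such as an amine, a methoxy group or a carboxylic acid, would give a clearly lower number than the methyl or the hydrogen.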